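A Hydroxypropyl Chain at the Cytotoxicity Limit

The source may report more compounds than this note shows. Statements on the series, on what has been measured and on what is new or still open speak of the compounds shown alone.

Compound 1 `COc1cc2cc(C#N)ccc2c(OC)c1Oc1cc(NCC2CC2)nc(Nc2ccc(C#N)cc2)n1`: > 125000 nM (a limit)
Compound 2 `COc1cc2cc(C#N)ccc2c(OC)c1Oc1cc(NC2CCOCC2)nc(Nc2ccc(C#N)cc2)n1`: > 125000 nM (a limit)
Compound 3 `COc1cc2cc(C#N)ccc2c(OC)c1Oc1cc(NCC2CCOC2)nc(Nc2ccc(C#N)cc2)n1`: > 125000 nM (a limit)

In an ADME assay on MT4 cells (Homo sapiens) for cytotoxicity, read by MTT assay, with a stated time of 5 days (on this read-out higher numbers stand for lower toxicity in this test and lower numbers for higher toxicity in this test), compound 3 gives > 125000 nM. This is a limit and not a number. The whole measured set sits together, at the limit of > 125000 nM in this assay, at which 3 of the 3 values shown sit.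

The next structure is compound 4 `COc1cc2cc(C#N)ccc2c(OC)c1Oc1cc(NCCCO)nc(Nc2ccc(C#N)cc2)n1`, and the change leading to it is 2-hydroxyethyl in place of oxolan-3-yl on a saturated chain carbon bound to a nitrogen on an aromatic ring. In words, 2-hydroxyethyl stands in place of oxolan-3-yl on a saturated chain carbon bound to a nitrogen on an aromatic ring, so that (oxolan-3-yl)methyl gives way to 3-hydroxypropyl.

Three measured exchanges bear on this place: a step that the two limits leave unreadable from compound 1 to compound 3, a step that the two limits leave unreadable from compound 1 to compound 2 and a step that the two limits leave unreadable from compound 2 to compound 3. None has a readable size, and none brought a value under the limit. Going by the values given here, compound 4 would be the only member with 3-hydroxypropyl, so the set offers no direct precedent for this group.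

On this evidence, no step beyond the scatter is expected in this assay, and another limit is the most likely report. The expected change is an at least 1.1-fold lower number from compound 3 to compound 4 (0.05 log units; that floor lies within the scatter). For compound 4 the estimated value is 110000 nM, with an expected range from 50000 nM to 125000 nM.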

Compound 4, half-maximal cytotoxic concentration: 23500 nM
The estimate for compound 4 lay 4.7-fold (0.67 log units) above the measured number; measured number below the stated range.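

In this assay, going by these compounds alone, the 3-hydroxypropyl chain of compound 4 is the first group on this nitrogen to bring a value under the limit, with an at least 5.3-fold lower number from compound 3 to compound 4 (0.72 log units; beyond the scatter) when 2-hydroxyethyl takes the place of oxolan-3-yl on the saturated chain carbon. The other two comparisons agree, with an at least 5.3-fold lower number from compound 2 to compound 4 (0.72 log units; beyond the scatter) when 3-hydroxypropyl replaces oxan-4-yl and an at least 5.3-fold lower number from compound 1 to compound 4 (0.72 log units; beyond the scatter) when 2-hydroxyethyl replaces cyclopropyl, so this position is not indifferent to its substituent in this test. The steps among compound 1, compound 2 and compound 3 cannot be read, and the three steps to compound 4 are floors that start from a limit: the limit of > 125000 nM in this assay, at which 3 of the 4 values shown sit.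

Compound 4 differs from the others both in having no ring in this substituent and in carrying a hydrogen-bond donor there, and the compounds shown do not separate these two differences. On these data alone, a 3-methoxypropyl chain, a plain propyl chain or a 3-aminopropyl chain on the same nitrogen remains open, as does whether a shorter or longer hydroxyalkyl chain would give a similar value.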